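Cyclohexyl for hexyl on the piperazine-bearing series

A few compounds are considered here, and "the series" means these few. Any claim that something is new, unique, unknown or untested is made for them only; others in the source may bear on it.

Compound 3 `CCCCCCN1CCN(CCC(=O)Nc2nc3c(C)cccc3s2)CC1` gives the lowest number of the three measured in an assay on membranes from liver for displacement of a labelled ligand from Sigma intracellular receptor 2 (Rattus norvegicus), read by scintillation counting, with a stated time of 120 min (a higher number here means a weaker inhibitor, a lower number a stronger inhibitor), at 158 nM. Compound 1 `CCN1CCN(CCC(=O)Nc2nc3c(C)cccc3s2)CC1` gives 1200 nM and compound 2 `CCCCN1CCN(CCC(=O)Nc2nc3c(C)cccc3s2)CC1` gives 1200 nM; the step of no change at the digits printed from compound 1 to compound 2 (within the scatter) stays within the scatter, while a 7.6-fold lower number from compound 1 to compound 3 (0.88 log units; beyond the scatter) and a 7.6-fold lower number from compound 2 to compound 3 (0.88 log units; beyond the scatter) both fall beyond it. Compound 4 `Cc1cccc2sc(NC(=O)CCN3CCN(C4CCCCC4)CC3)nc12` carries cyclohexyl in place of hexyl on an amine nitrogen in a ring. Among the compounds with values here, no measured step exchanges a chain for a ring; the measured steps only show that a longer chain gave a lower number, and compound 4 keeps the same count of carbon atoms as compound 3. The step of a 1.3-fold higher number from compound 3 to compound 4 (0.10 log units; within the scatter) is therefore expected to be small. Compound 4 is estimated at 200 nM in this assay, within 60 nM to 700 nM.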

Compound 4, inhibition constant: 233 nM
Beside the measured number, compound 4's estimate is 1.2-fold (0.07 log units) below it; the measured number falls inside the stated range.
By their numbers in this assay, from the lowest: compounds 3 and 4 (each within the scatter of the next); then compounds 1 and 2 (each within the scatter of the next).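

In this assay on the amine nitrogen in a ring, the open hexyl chain can give way to the cyclohexyl ring, as the step of a 1.5-fold higher number from compound 3 to compound 4 (0.17 log units; within the scatter) stays within the scatter. Cyclohexyl also keeps the distance from the shorter chains, with a 5.2-fold lower number from compound 2 to compound 4 (0.71 log units; beyond the scatter) and a 5.2-fold lower number from compound 1 to compound 4 (0.71 log units; beyond the scatter) both printed as beyond the scatter, so a low number here does not require an unbranched chain. No evidence bearing on this result is available. Still open, as far as these compounds go, is how a phenyl or benzyl group at this nitrogen would read, and whether an octyl chain would lower the number further.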